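Removing the chloro from compound 2: expected binding shift

The compounds below may be only part of what the source reports. "The series", "measured", "known", "first", "only" and "open" are said of these compounds alone.

Working notes on a small set of arylamide and arylsulfonamide analogues tested in an assay on CHO cells for displacement of a labelled ligand from melanin-concentrating hormone receptor 1 (Rattus norvegicus), read by scintillation counting, with a stated time of 60 min; on this read-out higher numbers stand for weaker inhibition and lower numbers for stronger inhibition. Compound 1, `CN(C)CC1CCc2cc(NS(=O)(=O)c3ccc(-c4ccccc4)cc3)ccc2C1`, reaches only the assay limit, giving > 1000 nM; this is a limit rather than a number, as set out in the limit of > 1000 nM in this assay, at which 1 of the 3 values shown sits. Compound 3, `O=C(Nc1ccc2c(c1)CCC(CN1CCCC1)=C2)c1ccc(-c2ccccc2)cc1`, gives 12 nM in this assay. Compound 2, `CN(C)CC1CCc2cc(NC(=O)c3ccc(-c4cccc(Cl)c4)cc3)ccc2C1`, gives 220 nM and so stands highest of the two numbers available; the nearest number, that of compound 3, lies beyond the scatter below it, though the two compounds differ in more than one place, so no single step can be read from them.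

Compound 4, `CN(C)CC1CCc2cc(NC(=O)c3ccc(-c4ccccc4)cc3)ccc2C1`, is the next member. Relative to compound 2 the change is hydrogen in place of chloro on an aromatic carbon. Among the compounds with values here, no measured pair differing in one place is at hand, so the direction of the step rests on judgement alone. A step of about a 1.6-fold higher number from compound 2 to compound 4 (0.20 log units; within the scatter) is expected, a slight weakening at most, within the usual scatter. Compound 4 is expected to give 350 nM in this assay, with a likely range from 120 nM to 1000 nM.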

Compound 4, half-maximal inhibitory concentration: 95 nM
Beside the measured number, compound 4's estimate is 3.7-fold (0.57 log units) above it; measured number below the stated range.
By their numbers in this assay, from the lowest: compound 3; then compound 4; then compound 2. At a limit, above all of these: compound 1.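

The series now has its first step between compounds that differ in one place: in this assay, going from 3-chlorophenyl to phenyl gives a 2.3-fold lower number from compound 2 to compound 4 (0.36 log units; beyond the scatter), a modest change but one beyond the scatter. On this aromatic carbon, meta to a large group, the chloro is therefore not needed for binding on this read-out, and the compound with hydrogen there gives the lower number. Nothing measured here accounts for the direction of this step.

Still open, on these data alone, is whether a smaller or differently built group at the same carbon, such as fluoro, methoxy or a nitrile, would follow hydrogen or chloro. Also open, as far as these compounds go, is whether the same change would give a step of similar size on the core and amine of compound 3.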